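The source may hold more compounds than are shown below. What is called first, only, known or untested is meant among the compounds shown, and "the series" means these compounds.

Compound 1 `O=C1Nc2c(ccc(F)c2F)C1(c1ccccc1)c1ccc(O)cc1`: 7.1 nM
Compound 2 `CCOc1ccc(C2(c3ccc(O)cc3)C(=O)Nc3c2ccc(F)c3F)cc1`: 11 nM
Compound 3 `CCCOc1ccc(C2(c3ccc(O)cc3)C(=O)Nc3c2ccc(F)c3F)cc1`: 356 nM

All three were measured in a functional assay on MCF7 cells (Homo sapiens) for cytotoxicity, read by WST assay, with a stated time of 72 h (on this read-out lower numbers stand for stronger inhibition and higher numbers for weaker inhibition), where compound 3 has the highest number and so is the weakest. Compound 4 `CCCCCOc1ccc(C2(c3ccc(O)cc3)C(=O)Nc3c2ccc(F)c3F)cc1` lengthens its chain from propyl to pentyl: ethyl in place of hydrogen on a saturated chain carbon, three bonds along the chain from an oxygen on an aromatic ring. Within the data shown here, two measured steps bear most directly on this. Adding ethoxy changed little, a 1.5-fold higher number from compound 1 to compound 2 (0.19 log units; within the scatter), while adding one more carbon to the chain changed much, a 32-fold higher number from compound 2 to compound 3 (1.51 log units; beyond the scatter). The total from the unsubstituted compound is a 50-fold higher number from compound 1 to compound 3 (1.70 log units; beyond the scatter). The rise is therefore not steady, and compound 2 goes against any simple rule about chain length. Even so, a further rise is expected, a 3.4-fold higher number from compound 3 to compound 4 (0.53 log units; beyond the scatter). The estimate for compound 4 is 1200 nM, with an expected range from 250 nM to 6000 nM.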

Compound 4, half-maximal inhibitory concentration: > 1000 nM
Compound 4: no number, only a limit; the forecaster's own chance of this, stated with the estimate: 15%; the middle value is on the limit's open side.
By their numbers in this assay, from the lowest: compounds 1 and 2 (each within the scatter of the next); then compound 3. At a limit, above all of these: compound 4.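

Compound 4 carries only a limit of the assay, not a number: the limit of > 1000 nM in this assay, at which 1 of the 4 values shown sits. Even so, the steps can be read as minimum sizes, and the number keeps rising as the chain grows from propyl to pentyl, with an at least 2.8-fold higher number from compound 3 to compound 4 (0.44 log units; beyond the scatter). The longer chain also stands far from the two strongest compounds, with an at least 90-fold higher number from compound 2 to compound 4 (1.95 log units; beyond the scatter) and an at least 140-fold higher number from compound 1 to compound 4 (2.14 log units; beyond the scatter).

From the compounds shown here alone, how far beyond its limit compound 4 lies remains unknown. Also open, going by these compounds, is where a butyl chain would fall, and whether an amine or a carboxylic acid on the chain would bring the number back down.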